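This account rests on a few compounds, and the source may have more. Where it says the series, first, only, none or still open, it means among the compounds named here.

In a functional assay on RAW264.7 cells (Mus musculus) for inhibition, with stated times of 1 h and 24 h (on this read-out higher numbers stand for weaker inhibition and lower numbers for stronger inhibition), compound 1 (`COc1cccc(-c2nn(-c3ccccc3)cc2-c2ccnc(NCCCNC(=O)c3cccc(C(F)(F)F)c3)c2)c1`) gives 5620 nM. Among the measured compounds shown here, compound 2 (`COc1ccc(C(=O)NCCCNc2cc(-c3cn(-c4ccccc4)nc3-c3cccc(OC)c3)ccn2)cc1`) gives 2940 nM, which places it within the scatter of the only other measured compound. Compound 3 (`COc1cccc(-c2nn(-c3ccccc3)cc2-c2ccnc(NCCCNC(=O)Nc3ccc(Cl)c(Cl)c3)c2)c1`) has (3,4-dichlorophenyl)amino in place of 4-methoxyphenyl on a carbonyl carbon. For the measured compounds named here, only one measured step bears on this change. In a 1.9-fold lower number from compound 1 to compound 2 (0.28 log units; within the scatter), 4-methoxyphenyl replaced 3-(trifluoromethyl)phenyl at the same carbonyl carbon, and the numbers stayed within the scatter. Going by the values given here, that step offers only indirect guidance, since no measured compound carries an amino group on this carbonyl carbon. A change beyond the scatter is therefore not expected in this assay, and the estimated step is a 1.2-fold lower number from compound 2 to compound 3 (0.07 log units; within the scatter). The data leave this estimate loose. For compound 3, the expected value is 2500 nM, within an estimated range of 800 nM to 7500 nM.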

Compound 3, half-maximal inhibitory concentration: 4210 nM
Compound 3: the middle estimate sits 1.7-fold (0.23 log units) below what was measured; low and high end bracket the measured number.
By their numbers in this assay, from the lowest: compounds 2, 3 and 1 (each within the scatter of the next).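

In this assay, this carbonyl carbon accepts (3,4-dichlorophenyl)amino, which counts one hydrogen-bond donor where 4-methoxyphenyl counts none, with a 1.4-fold higher number from compound 2 to compound 3 (0.16 log units; within the scatter) and with a 1.3-fold lower number from compound 1 to compound 3 (0.13 log units; within the scatter). The change thus puts a nitrogen on this carbon in place of a directly attached phenyl ring, and the three compounds still cannot be told apart in this assay, so this position has not yet shown a change beyond the scatter. Nothing measured alongside these numbers offers an explanation for this result.

Still open, from the compounds shown here alone, is whether this carbonyl carbon would give a different number with a group lacking an aromatic ring, such as a plain amine or a longer alkyl chain, or with a carboxylic acid on the phenyl ring. Also open, going by these compounds, is whether the two chlorines contribute anything on the phenylamino group.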